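Chain-length redistribution at the piperazine side chain

The source may report more compounds than this note shows. Statements on the series, on what has been measured and on what is new or still open speak of the compounds shown alone.

The shared core, seen in compound 1 `CN1CCN(CCCCCCn2c3c(c4ccccc42)C(=O)c2c[n+]([O-])c4ccccc4c2C3=O)CC1`, carries its substituent on an aromatic nitrogen. Among the measured compounds shown here, in a functional assay on MCF7 cells (Homo sapiens) for cytotoxicity, read by MTT assay, with a stated time of 72 h (a lower number here means a stronger inhibitor, a higher number a weaker inhibitor), compound 1 gives 400 nM, the lowest of the three numbers so far. Compound 2 `CC1(C)O[C@@H](CO)[C@H](Cn2cc(Cn3c4c(c5ccccc53)C(=O)c3c[n+]([O-])c5ccccc5c3C4=O)nn2)O1` gives 690 nM in this assay, within the scatter of compound 1. Compound 3 `O=C1c2c[n+]([O-])c3ccccc3c2C(=O)c2c1c1ccccc1n2Cc1cn([C@H]2O[C@H](CO)[C@@H](O)[C@H]2O)nn1` gives 1490 nM in this assay, beyond the scatter from compound 1.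

For the measured compounds named here, the one step that differs in a single place, a 2.2-fold higher number from compound 2 to compound 3 (0.33 log units; beyond the scatter), concerns the group on the triazole and not the side chain on the core's aromatic nitrogen; it therefore does not bear on the present change.

Compound 4 `CCCN1CCN(CCCCn2c3c(c4ccccc42)C(=O)c2c[n+]([O-])c4ccccc4c2C3=O)CC1` differs from compound 1 as follows: 4-propylpiperazin-1-yl in place of 2-(4-methylpiperazin-1-yl)ethyl on a saturated chain carbon, four bonds along the chain from an aromatic nitrogen. The same atoms are present, only joined differently, so the total size of the side chain is unchanged. Going by the values given here, no measured pair tests a shift of chain length between the linker and the piperazine nitrogen, and the difference between compound 1 and compound 2 is within the scatter. The expectation for compound 4 in this assay is therefore a step of a 1.1-fold higher number from compound 1 to compound 4 (0.05 log units; within the scatter), that is, none beyond the scatter. Compound 4 is estimated at 450 nM, with a range from 200 nM to 1000 nM.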

Compound 4, half-maximal inhibitory concentration: 1280 nM
Beside the measured number, compound 4's estimate is 2.8-fold (0.45 log units) below it; measured number outside the range, above it.
By their numbers in this assay, from the lowest: compounds 1, 2, 4 and 3 (each within the scatter of the next, the first and the last beyond it).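

At this position, on a saturated chain carbon, four bonds along the chain from an aromatic nitrogen, replacing 2-(4-methylpiperazin-1-yl)ethyl with 4-propylpiperazin-1-yl is not a neutral exchange in this assay: the step is a 3.2-fold higher number from compound 1 to compound 4 (0.51 log units; beyond the scatter). The two groups have the same heavy atoms and the same counts of donors and acceptors, so for this pair, those counts do not fix the number; how the same atoms are arranged around the piperazine ring does change it. This is the first pair shown that reads a change in this side chain, and no available measurement bears on why the number moves.

Going by these compounds, the pair shortens the chain on the aromatic nitrogen and lengthens the alkyl group on the piperazine in a single change, so the contribution of each stays open; a 4-(4-methylpiperazin-1-yl)butyl group on the aromatic nitrogen would separate the two. Also open, on these data alone, is whether the step holds for other chain ends, such as a morpholine ring or a piperazine with a free amine.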